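The source may hold more compounds than are shown below. What is called first, only, known or untested is meant among the compounds shown, and "the series" means these compounds.

Measured compounds:
Compound 1, `Clc1ccc(/N=N/N2CCCCC2)cc1`: in an ADME assay on Vero cells (Chlorocebus sabaeus) for cytotoxicity, read by crystal violet staining (on this read-out lower numbers stand for higher toxicity in this test and higher numbers for lower toxicity in this test), compound 1 gives > 100000 nM, which is a limit of the assay and not a number.
Compound 2, `O=[N+]([O-])c1ccc(/N=N/N2CCCC2)cc1`: in this assay compound 2 gives 90000 nM.

Compound 2 thus holds the only number shown in this assay; the one further value is a limit. Among the compounds with values here, no step between measured compounds differing in one place is available, so there is no measured guide for the change that leads to compound 3, `Clc1ccc(/N=N/N2CCCC2)cc1`.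

Compound 3 differs from compound 2 in one place: chloro in place of nitro on an aromatic carbon. The change sits on an aromatic carbon of a six-membered aromatic ring of carbon only, para to a group of 7 heavy atoms.

Both measured compounds show weak toxicity in this assay, one of them only as a limit. For that reason the step from compound 2 to compound 3 is expected to be small, toward lower toxicity or none beyond the scatter, as a 1.3-fold higher number from compound 2 to compound 3 (0.12 log units; within the scatter). Compound 3 is accordingly estimated at 120000 nM, within 50000 nM to 300000 nM, with a fair chance that only a limit is reported.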

Compound 3, half-maximal cytotoxic concentration: > 100000 nM
Compound 3: only a limit was reported; the forecaster's own chance of this, stated with the estimate: 55%; the middle value is on the limit's open side.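

In this assay, within the data shown here, chloro in place of nitro on an aromatic carbon, para to a group of 7 heavy atoms, gives the first step that can be read at this position: an at least 1.1-fold higher number from compound 2 to compound 3 (0.04 log units; that floor lies within the scatter). Compound 3 gives > 100000 nM, which is a limit of the assay and not a number. The change therefore shows that, with chloro at this place, the shared core stays at the limit of the test, and the step can be given only as a floor because the values crowd against that limit: the limit of > 100000 nM in this assay, at which 2 of the 3 values shown sit.

Steps between compounds that carry only limits cannot be read, so compound 1 and compound 3 cannot be set against each other. Still open, from the compounds shown here alone, is how far past the limit compound 3 truly lies in this assay, and whether an amine or a carboxylic acid on the same aromatic carbon would yield a measured number there.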